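Shortening the side chain of compound 3

The source may hold more compounds than are shown below. What is called first, only, known or untested is meant among the compounds shown, and "the series" means these compounds.

Within the data shown here, compound 3 `C/N=C(\S)NCCCCn1nc(-c2ccccc2)ccc1=O` gives 17.3 mg/kg in a functional assay on the whole organism with Rattus norvegicus as the target (a higher number here means that more compound is needed for the effect, a lower number that less compound is needed), the lowest of the three numbers so far. Compound 2 `N#CNC(=N)NCCCCn1nc(-c2ccccc2)ccc1=O` gives 59.3 mg/kg and compound 1 `CC/N=C(/NC#N)NCCCn1nc(-c2ccccc2)ccc1=O` gives 88.5 mg/kg; the steps are a 3.4-fold lower number from compound 2 to compound 3 (0.54 log units; beyond the scatter) and a 5.1-fold lower number from compound 1 to compound 3 (0.71 log units; beyond the scatter). Compound 4 `C/N=C(\S)NCCCn1nc(-c2ccccc2)ccc1=O` differs from compound 3 by a group of 5 heavy atoms (2 carbon, 2 nitrogen, 1 sulfur; no ring) in place of a group of 6 heavy atoms (3 carbon, 2 nitrogen, 1 sulfur; no ring), on a saturated chain carbon, three bonds along the chain from an aromatic nitrogen. Among the measured compounds shown here, the only measured step at that place is a 1.5-fold lower number from compound 1 to compound 2 (0.17 log units; within the scatter), and that step also alters the group itself, so no pair in the set changes the chain alone. In this assay a step of about that size, or none beyond the scatter, is therefore expected, with the number for compound 4 if anything somewhat higher. The estimate for compound 4 is 22 mg/kg, range 9 mg/kg to 55 mg/kg, meaning a 1.3-fold higher number from compound 3 to compound 4 (0.10 log units; within the scatter).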

Compound 4, dose for half-maximal effect: 58 mg/kg
The estimate for compound 4 lay 2.6-fold (0.42 log units) below the measured number; measured number above the stated range.
By their numbers in this assay, from the lowest: compound 3; then compounds 4, 2 and 1 (each within the scatter of the next).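

Shortening the chain alone gives a 3.4-fold higher number from compound 3 to compound 4 (0.53 log units; beyond the scatter) in this assay, so at this place chain length matters for the sulfur-bearing group. Against the nitrile-bearing compounds, a 1.0-fold lower number from compound 2 to compound 4 (0.01 log units; within the scatter) and a 1.5-fold lower number from compound 1 to compound 4 (0.18 log units; within the scatter) both stay within the scatter, so among these compounds only compound 3, with the longer chain and the sulfur-bearing group together, stands apart. No measurement at hand gives a reason for this step.

Going by these compounds, whether a still longer chain would lower the number further remains open. So does whether an amine at the chain end would respond to chain length in the same way.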